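A few compounds are considered here, and "the series" means these few. Any claim that something is new, unique, unknown or untested is made for them only; others in the source may bear on it.

Compound 1 `O=S(=O)(Nc1ccc2[nH]c(Cc3ccc(Oc4ccccc4)cc3)nc2c1)c1ccccc1` gave 14000 nM in an assay on membranes from brain for binding affinity to Adrenergic receptor alpha-1 (Rattus norvegicus); on this read-out lower numbers stand for stronger inhibition and higher numbers for weaker inhibition.
Compound 2 `CC(=O)Nc1ccc2[nH]c(Cc3ccc(Oc4ccccc4)cc3)nc2c1` gave 20000 nM in this assay.

Compound 2 holds the higher of the two numbers, but its nearest neighbour, compound 1, lies within the scatter of it: the step of a 1.4-fold higher number from compound 1 to compound 2 (0.15 log units; within the scatter) is too small to count as a change in either direction. Compound 3 `CN(c1ccc2[nH]c(Cc3ccc(Oc4ccccc4)cc3)nc2c1)S(C)(=O)=O` departs from compound 2 at the same position on the shared core: methyl(methylsulfonyl)amino in place of acetamido on an aromatic carbon. For the measured compounds named here, the only measured step that bears on this position is the one from compound 1 to compound 2, and that step, a 1.4-fold higher number from compound 1 to compound 2 (0.15 log units; within the scatter), stayed within the scatter even though it swapped a phenylsulfonyl for an acetyl on that nitrogen. The change to compound 3 is a different one, as the two substituents of the nitrogen are both new, so the earlier step is only a rough guide. With nothing in the measured pair pointing up or down, the expected step of a 1.3-fold lower number from compound 2 to compound 3 (0.10 log units; within the scatter) is none beyond the scatter. Compound 3 is therefore estimated at 16000 nM, with a range from 5000 nM to 50000 nM.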

Compound 3, half-maximal inhibitory concentration: 2000 nM
The estimate for compound 3 lay 8.0-fold (0.90 log units) above the measured number, outside the stated range (below it).
By their numbers in this assay, from the lowest: compound 3; then compounds 1 and 2 (each within the scatter of the next).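

This position on the shared core can clearly move the number in this assay: methyl(methylsulfonyl)amino in place of acetamido gives a 10-fold lower number from compound 2 to compound 3 (1.00 log units; beyond the scatter), and the same group in place of (phenylsulfonyl)amino gives a 7.0-fold lower number from compound 1 to compound 3 (0.85 log units; beyond the scatter), while the exchange of the two earlier substituents stayed within the scatter. Compounds 1 and 2 both keep a hydrogen on this nitrogen and differ in what is attached to it, whereas compound 3 carries a methyl there as well as a methylsulfonyl, so the lower number goes with this doubly substituted nitrogen, though three compounds are too few to make that a rule. Nothing in the data at hand gives a reason for this shift.

Still open, going by these compounds, is which part of the new group goes with the lower number, the methyl on the nitrogen or the methylsulfonyl, since the two enter together. Also open, on these data alone, is how a longer chain such as ethyl on that nitrogen, or a free amine at this position, would read in this assay.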